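The source may report more compounds than this note shows. Statements on the series, on what has been measured and on what is new or still open speak of the compounds shown alone.

Among the measured compounds shown here, compound 2 `N#CC1=C(N)Oc2c(c3nc4ccccc4nc3c3ccccc23)C12C(=O)N(Cc1cnnn1-c1ccc(N)cc1)c1ccccc12` is the only member of the pair with a numerical read-out: in a functional assay on HCT-116 cells (Homo sapiens) for antiproliferative activity, read by MTT assay, with a stated time of 48 h (on this read-out lower numbers stand for stronger inhibition and higher numbers for weaker inhibition), compound 2 gives 45200 nM. Compound 1 `Cc1cccc(-n2nncc2CN2C(=O)C3(C(C#N)=C(N)Oc4c3c3nc5ccccc5nc3c3ccccc43)c3ccccc32)c1` reaches only > 50000 nM in this assay, which is a limit of the assay. For the measured compounds named here, the single measured step, an at least 1.1-fold lower number from compound 1 to compound 2 (0.04 log units; that floor lies within the scatter), therefore rests on one limit and one weak value (the limit of > 50000 nM in this assay, at which 1 of the 2 values shown sits); it leaves compound 2 with weak inhibition, and its size cannot be read as a change beyond the scatter.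

Compound 3 `N#CC1=C(N)Oc2c(c3nc4ccccc4nc3c3ccccc23)C12C(=O)N(Cc1cnnn1-c1ccc(F)c(Cl)c1)c1ccccc12` keeps the shared core and alters the group on the aromatic nitrogen: 3-chloro-4-fluorophenyl in place of 4-aminophenyl on an aromatic nitrogen. Going by the values given here, the only measured step that bears on this position is an at least 1.1-fold lower number from compound 1 to compound 2 (0.04 log units; that floor lies within the scatter), where exchanging one phenyl substituent for another did not move the number beyond the scatter. No step beyond the scatter is thus expected from compound 2 to compound 3 in this assay, and the estimated change is a 1.1-fold lower number from compound 2 to compound 3 (0.05 log units; within the scatter). Compound 3 is expected to give 40000 nM in this assay, with an estimated range from 15000 nM to 100000 nM, a limit read-out remaining a real possibility.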

Compound 3, half-maximal inhibitory concentration: > 50000 nM
Compound 3 was reported as a limit; the forecaster's own chance of this, stated with the estimate: 40%; middle value at least 1.2-fold (0.09 log units) away from the limit.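

Replacing 4-aminophenyl with 3-chloro-4-fluorophenyl on the aromatic nitrogen gives an at least 1.1-fold higher number from compound 2 to compound 3 (0.04 log units; that floor lies within the scatter) in this assay, so this readable floor does not separate the two groups, although the entering group has 0 hydrogen-bond donors and the leaving group has 1. Compared with the earlier exchange of one phenyl substituent for another, this result extends the test to a phenyl ring carrying two halogens, and the read-out still gives no step shown to lie beyond the scatter. The step between compound 1 and compound 3 cannot be read, and the position now shows mainly limit read-outs rather than a graded series: the limit of > 50000 nM in this assay, at which 2 of the 3 values shown sit.

Among the compounds shown here, compound 2 remains the only member with a numerical read-out, at 45200 nM, which leaves no measured basis for ranking the three substituted phenyl groups. Going by these compounds, it remains open whether a carboxylic acid on the phenyl ring, or a longer alkyl chain in place of that ring, would bring this position to a clearly numerical value in this assay.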